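A few compounds are considered here, and "the series" means these few. Any claim that something is new, unique, unknown or untested is made for them only; others in the source may bear on it.

Series notes, values in a functional assay on MT2 cells (Homo sapiens) for cytotoxicity, read by MTT assay; a lower number here means that less compound is tolerated, a higher number that more compound is tolerated:
- compound 1 `COc1ccc(Nc2nccs2)cc1OCC=C(C)C`: 42000 nM
- compound 2 `CCc1ccc(Nc2nccs2)cc1OCC=C(C)C`: 31000 nM
- compound 3 `CCCc1ccc(Nc2nccs2)cc1OCC=C(C)C`: 23000 nM

In this assay, among the compounds with values here, compound 3 gives 23000 nM, and no measured step separates it from compound 1 or compound 2 beyond the scatter.

The next change leads to compound 4 `CC(C)=CCOc1cc(Nc2nccs2)ccc1C(=O)O`: carboxy in place of propyl on an aromatic carbon. In words, this is carboxy in place of propyl on an aromatic carbon, ortho to a (3-methylbut-2-en-1-yl)oxy group and para to a (1,3-thiazol-2-yl)amino group.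

All three measured steps concern this same carbon: a 1.4-fold lower number from compound 1 to compound 2 (0.13 log units; within the scatter), a 1.8-fold lower number from compound 1 to compound 3 (0.26 log units; within the scatter) and a 1.3-fold lower number from compound 2 to compound 3 (0.13 log units; within the scatter). They show that exchanging methoxy, ethyl and propyl there left this assay within the scatter. Within the data shown here, none of them brings in a carboxy, so they give the size of earlier changes but no direct precedent for this one. The direction therefore rests on judgement, not on a measured step: a higher number is expected, meaning more compound tolerated, with a step that may go somewhat beyond the scatter.

The expected step is a 3.0-fold higher number from compound 3 to compound 4 (0.48 log units; beyond the scatter). The estimate for compound 4 is 70000 nM, with an expected range of 25000 nM to 200000 nM.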

Compound 4, half-maximal cytotoxic concentration: 17000 nM
Compound 4: the middle estimate sits 4.1-fold (0.61 log units) above what was measured; measured number outside the range, below it.
By their numbers in this assay, from the lowest: compounds 4, 3, 2 and 1 (each within the scatter of the next, the first and the last beyond it).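

In this assay, carboxy on this aromatic carbon, para to the (1,3-thiazol-2-yl)amino group, stays level with the alkyl groups: the exchange for propyl gives a 1.4-fold lower number from compound 3 to compound 4 (0.13 log units; within the scatter), and the exchange for ethyl gives a 1.8-fold lower number from compound 2 to compound 4 (0.26 log units; within the scatter). Only the exchange for methoxy goes beyond the scatter, with a 2.5-fold lower number from compound 1 to compound 4 (0.39 log units; beyond the scatter), a modest step and the only one at this carbon so far to do so, which shows that even a group as different in make-up from propyl as carboxy, with its two oxygens, changes little in this assay. Nothing measured here accounts for this flat response.

The compounds shown leave open whether an amine, a methyl ester of the carboxylic acid or a longer chain on this carbon would stay in the same narrow range in this assay. On these data alone, the (3-methylbut-2-en-1-yl)oxy group and the (1,3-thiazol-2-yl)amino group are common to all four compounds, so what either contributes to these numbers also remains open.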